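This account rests on a few compounds, and the source may have more. Where it says the series, first, only, none or still open, it means among the compounds named here.

Measured so far, in a physicochemical assay for solubility, read by HPLC, at pH 6.8; a lower number here means a less soluble compound, a higher number a more soluble compound:
compound 1 `CC(C)CN1CCCC[C@H]1C(=O)Nc1cc(C(C)(C)C)on1` gives 32 ug/mL;
compound 2 `CC(C)(C)c1cc(NC(=O)[C@@H]2CCCCN2CC2CCOCC2)no1` gives 72 ug/mL.

Compound 1 stands lowest of the two numbers; its nearest neighbour is compound 2, reached by a 2.3-fold higher number from compound 1 to compound 2 (0.35 log units; beyond the scatter). Compound 3 `CC(C)(C)c1cc(NC(=O)[C@@H]2CCCCN2C(=O)C2CCOCC2)no1` differs from compound 1 in one place: (oxan-4-yl)carbonyl in place of isobutyl on an amine nitrogen in a ring. Among the compounds with values here, only the step of a 2.3-fold higher number from compound 1 to compound 2 (0.35 log units; beyond the scatter) bears on this, and only in part: there the oxan-4-yl entered on a saturated chain carbon bound to the amine nitrogen, whereas here an (oxan-4-yl)carbonyl enters on the amine nitrogen in the ring itself. A modest rise is therefore expected, with wide uncertainty. Compound 3 is estimated at 50 ug/mL, range 20 ug/mL to 130 ug/mL, a step of a 1.6-fold higher number from compound 1 to compound 3 (0.19 log units; within the scatter).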

Compound 3, solubility: 48 ug/mL
Compound 3: the middle estimate sits 1.0-fold (0.02 log units) above what was measured; measured number inside the range.
By their numbers in this assay, from the lowest: compounds 1, 3 and 2 (each within the scatter of the next, the first and the last beyond it).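

In this assay, (oxan-4-yl)carbonyl on the amine nitrogen in the ring gives a 1.5-fold higher number from compound 1 to compound 3 (0.18 log units; within the scatter), and the same group in place of (oxan-4-yl)methyl gives a 1.5-fold lower number from compound 2 to compound 3 (0.18 log units; within the scatter). Compound 3 therefore cannot be told apart from either compound 1 or compound 2, although those two stand apart from each other, so the carbonyl form adds no step beyond the scatter at this position. No evidence is available that explains this result.

Going by these compounds, it remains open whether a longer chain or a carboxylic acid in place of the (oxan-4-yl)carbonyl on the amine nitrogen would move the number beyond the scatter.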